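Replacing methoxy with bromo in an antiproliferative series

A few compounds are considered here, and "the series" means these few. Any claim that something is new, unique, unknown or untested is made for them only; others in the source may bear on it.

In a functional assay on MCF7 cells (Homo sapiens) for antiproliferative activity, read by MTT assay, with a stated time of 48 h (on this read-out higher numbers stand for weaker inhibition and lower numbers for stronger inhibition), compound 1 (`COc1ccc(/C=C/C(=O)Nc2cc(-c3ccc(Br)cc3)[nH]n2)cc1`) gives 590 nM and compound 2 (`O=C(/C=C/c1ccc(Cl)cc1)Nc1cc(-c2ccccc2)[nH]n1`) gives 970 nM on the same read-out. Within the data shown here, these two numbers lie within the usual scatter of each other, so compound 1 stands level with the only other measured compound and the two cannot be ranked.

Compound 3 (`O=C(/C=C/c1ccc(Br)cc1)Nc1cc(-c2ccc(Br)cc2)[nH]n1`) has not yet been measured. It differs from compound 1 in one place, on an aromatic carbon of a six-membered aromatic ring of carbon only, para to a large group. There, bromo stands in place of methoxy, turning 4-methoxyphenyl into 4-bromophenyl (bromo in place of methoxy on an aromatic carbon).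

Among the measured compounds shown here, no measured pair isolates this change, so the data give no direct guide to it. No step beyond the scatter is expected in this assay in either direction, since compound 2, which has no methoxy group, gives 970 nM and stays within the scatter of compound 1, though it differs in other ways too. The expected size is a 1.2-fold lower number from compound 1 to compound 3 (0.07 log units; within the scatter) at this estimate. Compound 3 is estimated at 500 nM (range 180 nM to 1400 nM).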

Compound 3, half-maximal inhibitory concentration: 920 nM
For compound 3 the middle estimate is 1.8-fold (0.26 log units) below the measured one, within the range that was stated.
By their numbers in this assay, from the lowest: compounds 1, 3 and 2 (each within the scatter of the next).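

In this assay, among these compounds, compound 1 and compound 3 form the first pair that isolates bromo in place of methoxy on an aromatic carbon, and the step is a 1.6-fold higher number from compound 1 to compound 3 (0.19 log units; within the scatter). This position therefore accepts either 4-methoxyphenyl or 4-bromophenyl with the two compounds standing level, and the hydrogen-bond acceptor that leaves with the methoxy is not needed for a value in this range, at least with the rest of compound 1 held fixed. Nothing available explains why these two groups read alike.

The compounds shown leave open whether this position would stay as accepting with a hydroxyl, an amine, a carboxylic acid or a longer chain such as butoxy in place of the methoxy or bromo, since only these two groups can be compared here. They also leave open whether the same exchange would read alike on a core lacking the bromo of the other phenyl ring, since compound 1 and compound 3 both carry it and compound 2 differs from each of them in more than one place.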